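From 3-methylbenzyl to (2,4,6-trimethylphenyl)sulfonyl on a ring nitrogen

This account rests on a few compounds, and the source may have more. Where it says the series, first, only, none or still open, it means among the compounds named here.

Compound 1 `COC(=O)c1ccc(C2SCC(=O)N2c2ccc(N3CCN(Cc4cccc(C)c4)CC3)cn2)c(OC)c1` was tested in a functional assay on Jurkat cells (Homo sapiens) for antiproliferative activity, read by MTT assay and trypan blue exclusion, with a stated time of 72 h; on this read-out lower numbers stand for stronger inhibition and higher numbers for weaker inhibition. For compound 1 the result is only a limit, > 100000 nM. Two relatives give numbers: compound 2 `COC(=O)c1ccc(C2SCC(=O)N2c2ccc(N3CCN(S(=O)(=O)c4ccc([N+](=O)[O-])cc4)CC3)cn2)c(OC)c1` gives 54000 nM, and compound 3 `COC(=O)c1ccc(C2SCC(=O)N2c2ccc(N3CCNCC3)cn2)c(OC)c1` gives 19300 nM. The step of an at least 1.8-fold lower number from compound 1 to compound 2 (0.26 log units; that floor lies within the scatter) came with (4-nitrophenyl)sulfonyl in place of 3-methylbenzyl on an amine nitrogen in a ring; the step of an at least 5.1-fold lower number from compound 1 to compound 3 (0.71 log units; beyond the scatter) came with hydrogen in that place; and a 2.8-fold lower number from compound 2 to compound 3 (0.45 log units; beyond the scatter). Compound 4 `COC(=O)c1ccc(C2SCC(=O)N2c2ccc(N3CCN(S(=O)(=O)c4c(C)cc(C)cc4C)CC3)cn2)c(OC)c1` differs from compound 1 thus: (2,4,6-trimethylphenyl)sulfonyl in place of 3-methylbenzyl on an amine nitrogen in a ring. The closest measured guide is an at least 1.8-fold lower number from compound 1 to compound 2 (0.26 log units; that floor lies within the scatter), another sulfonyl on the same nitrogen. For compound 4 a similar, at most modest move to a lower number is therefore expected, an at least 1.6-fold lower number from compound 1 to compound 4 (0.22 log units; that floor lies within the scatter). Compound 4 is estimated at 60000 nM, between 20000 nM and 200000 nM.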

Compound 4, half-maximal inhibitory concentration: > 100000 nM
Compound 4 was reported as a limit (the forecaster's own chance of this, stated with the estimate: 35%); middle value at least 1.6-fold (0.22 log units) away from the limit.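

In this assay, (2,4,6-trimethylphenyl)sulfonyl in place of hydrogen on the ring nitrogen gives an at least 5.1-fold higher number from compound 3 to compound 4 (0.71 log units; beyond the scatter), so all three groups shown on this nitrogen now give higher numbers than hydrogen. Changing only the group on the sulfonyl sulfur, 2,4,6-trimethylphenyl in place of 4-nitrophenyl, gives an at least 1.8-fold higher number from compound 2 to compound 4 (0.26 log units; that floor lies within the scatter), so no firm difference between these two sulfonyl groups is shown. The step between compound 1 and compound 4 cannot be read, as each result is only a limit: the limit of > 100000 nM in this assay, at which 2 of the 4 values shown sit.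

From the compounds shown here alone, it remains open whether a small group on this nitrogen, such as methyl or acetyl, would keep the number of compound 3 or lower it.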